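A few compounds are considered here, and "the series" means these few. Any claim that something is new, unique, unknown or untested is made for them only; others in the source may bear on it.

Measured compounds:
compound 1, `CCNC(=O)c1cc(Oc2ccc(NC(=O)c3cc4cccnc4n(-c4ccc(Cl)cc4)c3=O)cc2)ccn1`, 250 nM in a functional assay on A549 cells (Homo sapiens) for antiproliferative activity, read by MTT assay, with a stated time of 72 h; on this read-out lower numbers stand for stronger inhibition and higher numbers for weaker inhibition
compound 2, `CCNC(=O)c1cc(Oc2ccc(NC(=O)c3cc4cccnc4n(-c4ccc(Br)cc4)c3=O)cc2)ccn1`, 910 nM in this assay

Within the data shown here, compound 1 has the lowest of the two numbers; the only measured step is a 3.6-fold higher number from compound 1 to compound 2 (0.56 log units; beyond the scatter), a swap of one halogen for another. Compound 3, `CCCNC(=O)c1cc(Oc2ccc(NC(=O)c3cc4cccnc4n(-c4ccc(Cl)cc4)c3=O)cc2)ccn1`, differs from compound 1 by methyl in place of hydrogen on a saturated chain carbon, two bonds along the chain from an amide-type nitrogen. Among the measured compounds shown here, no measured step touches this chain, so the halogen step gives no guidance here, and no change beyond the usual scatter is expected. Compound 3 is therefore estimated at 300 nM, with a range of 120 nM to 900 nM. This estimate means a 1.2-fold higher number from compound 1 to compound 3 (0.08 log units; within the scatter).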

Compound 3, half-maximal inhibitory concentration: 120 nM
Compound 3: middle estimate off by 2.5-fold (0.40 log units), on the high side, within the range that was stated.
By their numbers in this assay, from the lowest: compound 3; then compound 1; then compound 2.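

In this assay, among these compounds, going from ethylamino to propylamino gives a 2.1-fold lower number from compound 1 to compound 3 (0.32 log units; beyond the scatter), so this chain, which no earlier step touched, does affect the number, and the added methyl lowers it. The step is modest and rests on a single pair, with the chloro group held in place. No measurement here bears on the reason for this shift. From the compounds shown here alone, it remains open whether a longer chain such as butyl would lower the number further, and how a terminal amine or a carboxylic acid on this chain would compare.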